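A few compounds are considered here, and "the series" means these few. Any claim that something is new, unique, unknown or untested is made for them only; others in the source may bear on it.

Compound 1 `COc1ccc(Cn2c3c(c4ccccc4c2=O)CCOc2ccccc2-3)cc1` is the starting point. In a functional assay on HL-60 cells (Homo sapiens) for cytotoxicity, read by sulforhodamine B assay (a lower number here means a stronger inhibitor, a higher number a weaker inhibitor), compound 1 gives 4490 nM. Compound 2 `COc1ccc(Cn2c3c(c4cc(C)ccc4c2=O)CCOc2ccccc2-3)cc1` carries one change on the shared core, (methyl in place of hydrogen on an aromatic carbon), and in this assay compound 2 gives 9260 nM; the step of a 2.1-fold higher number from compound 1 to compound 2 (0.31 log units; beyond the scatter) goes toward weaker inhibition.

Compound 3 `C=COc1ccccc1-c1c(Br)c2ccccc2c(=O)n1Cc1ccc(OC)cc1` rests on a different core; how it differs from compound 1 is not broken down here. In this assay compound 3 gives 59500 nM, the highest number of the three measured compounds.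

Compound 4 `C=COc1ccccc1-c1c(Br)c2cc(C)ccc2c(=O)n1Cc1ccc(OC)cc1` has not yet been measured. It differs from compound 3 by methyl in place of hydrogen on an aromatic carbon. This is the same kind of change as that from compound 1 to compound 2, though the surroundings are not identical: in compound 2 the ring is part of a fused or bridged system of four rings, in compound 4 part of a fused or bridged system of two rings. Because a 2.1-fold higher number from compound 1 to compound 2 (0.31 log units; beyond the scatter) weakened inhibition, a step of similar size is expected, a 1.8-fold higher number from compound 3 to compound 4 (0.27 log units; within the scatter), and compound 4 is expected to give 110000 nM in this assay, between 40000 nM and 300000 nM.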

Compound 4, half-maximal inhibitory concentration: 29200 nM
Estimate against measurement, compound 4: 3.8-fold (0.58 log units) above; the whole stated range lies above it.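

In this assay, methyl in place of hydrogen on the aromatic carbon gives a 2.0-fold lower number from compound 3 to compound 4 (0.31 log units; beyond the scatter), a modest move toward stronger inhibition, whereas the same change on the other core gave a 2.1-fold higher number from compound 1 to compound 2 (0.31 log units; beyond the scatter), a modest move toward weaker inhibition. The two steps therefore point in opposite directions, and the gap between them is larger than repeat measurements would be expected to produce: the same change on two cores in this assay, a 2.1-fold higher number (0.31 log units; beyond the scatter) from compound 1 to compound 2 and a 2.0-fold lower number (0.31 log units; beyond the scatter) from compound 3 to compound 4, 4.2-fold (0.62 log units) apart, beyond the scatter of two such steps. Going by these compounds alone, this shows that the result of this change on one core could not be carried over to the other core here, but with only two pairs it does not show why the direction differs or how a further core would respond.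

As far as these compounds go, only hydrogen and methyl appear at this aromatic carbon, so it remains open how an ethyl group, a fluorine atom or an amine there would behave on either core. From the compounds shown here alone, it also remains open whether the two cores would part in the same way for any of these groups.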